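Methyl in place of hydrogen on the core of compound 2

A few compounds are considered here, and "the series" means these few. Any claim that something is new, unique, unknown or untested is made for them only; others in the source may bear on it.

In a functional assay on HepG2 cells (Homo sapiens) for antiproliferative activity, read by MTT assay, with a stated time of 72 h (on this read-out lower numbers stand for stronger inhibition and higher numbers for weaker inhibition), compound 2 `COc1cc(N(C)CCN(C)C)c(NC(=O)/C=C\C(C)C)cc1Nc1nccc(-c2cn(C)c3ccccc23)n1` gives 4390 nM, the highest of the two numbers shown. Compound 3 `COc1cc(N(C)CCN(C)C)c(NC(=O)/C=C\C(C)C)cc1Nc1ncc(C#N)c(-c2cn(C)c3ccccc23)n1` gives 1810 nM, and the step of a 2.4-fold lower number from compound 2 to compound 3 (0.38 log units; beyond the scatter) is modest. Compound 1 `COc1cc(N(C)CCN(C)C)c(NC(=O)C(Cl)=C(Cl)Cl)cc1Nc1nccc(-c2cn(C)c3ccccc23)n1` returns only a limit, > 50000 nM. The step of an at least 11-fold lower number from compound 1 to compound 2 (1.05 log units; beyond the scatter) starts from that limit (the limit of > 50000 nM in this assay, at which 1 of the 3 values shown sits). Compound 4 `COc1cc(N(C)CCN(C)C)c(NC(=O)/C=C\C(C)C)cc1Nc1nc(C)cc(-c2cn(C)c3ccccc23)n1` differs from compound 2 by methyl in place of hydrogen on an aromatic carbon. Of the measured steps, only the cyano change, also a substitution on the core ring, bears on this one, and it was modest; the amide change acts on another part of the molecule. Going by the values given here, no measured step covers a methyl at this place, so only a step within the scatter, in no fixed direction, is expected. The step is therefore expected to be a 1.1-fold lower number from compound 2 to compound 4 (0.04 log units; within the scatter). Compound 4 is therefore estimated at 4000 nM, between 1500 nM and 12000 nM.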

Compound 4, half-maximal inhibitory concentration: 3550 nM
The estimate for compound 4 lay 1.1-fold (0.05 log units) above the measured number; the range from low to high includes it.
By their numbers in this assay, from the lowest: compounds 3, 4 and 2 (each within the scatter of the next, the first and the last beyond it). At a limit, above all of these: compound 1.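

In this assay, methyl in place of hydrogen on the aromatic carbon next to the ring nitrogen gives a 1.2-fold lower number from compound 2 to compound 4 (0.09 log units; within the scatter) and so leaves the number within the scatter. This position on the shared core therefore accepts a methyl with no measurable gain or loss in this assay. Nothing shown gives a cause for this step.

As far as these compounds go, whether a longer chain, an amine or a carboxylic acid at this position would behave like methyl remains open. Also open, from the compounds shown here alone, is how methyl here combines with the nitrile of compound 3.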